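Methyl to trifluoromethyl on compound 3

The compounds below may be only part of what the source reports. "The series", "measured", "known", "first", "only" and "open" are said of these compounds alone.

Values so far in a functional assay on HepG2 cells (Homo sapiens) for antiproliferative activity, read by MTT assay, with a stated time of 48 h (on this read-out lower numbers stand for stronger inhibition and higher numbers for weaker inhibition), are:
- compound 1 `CCCCCCCCCCCCOc1ccc(C(=O)/C=C/c2c(/C=C/c3ccc(OC)cc3)cc(OC)cc2OC)cc1` gives 11.6 ug/mL
- compound 2 `COc1ccc(/C=C/c2cc(OC)cc(OC)c2/C=C/C(=O)c2ccc(Cl)c(Cl)c2)cc1` gives 10.8 ug/mL
- compound 3 `COc1ccc(/C=C/c2cc(OC)cc(OC)c2/C=C/C(=O)c2ccc(C)cc2)cc1` gives 4.8 ug/mL

Compound 3 has the lowest number of the three in this assay and so is the strongest inhibitor here, with compound 1 and compound 2 both clearly higher. Compound 4 `COc1ccc(/C=C/c2cc(OC)cc(OC)c2/C=C/C(=O)c2ccc(C(F)(F)F)cc2)cc1` keeps the shared core and changes in one place: trifluoromethyl in place of methyl on an aromatic carbon with trifluoromethyl in place of methyl on an aromatic carbon, para to a large group.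

Within the data shown here, no measured compound carries trifluoromethyl, so only one step offers a guide. That step is a 2.3-fold lower number from compound 2 to compound 3 (0.35 log units; beyond the scatter) with 4-methylphenyl in place of 3,4-dichlorophenyl on a carbonyl carbon, and it is modest. It suggests that replacing the methyl with a halogen-bearing group may move the number back up, though one step is thin evidence. The expected change is a 1.6-fold higher number from compound 3 to compound 4 (0.19 log units; within the scatter) which would be a modest rise at most. Compound 4 is estimated at 7.5 ug/mL with a range from 3.5 ug/mL to 15 ug/mL expected for it.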

Compound 4, half-maximal inhibitory concentration: 18.7 ug/mL
For compound 4 the middle estimate is 2.5-fold (0.40 log units) below the measured one, outside the stated range (above it).
By their numbers in this assay, from the lowest: compound 3; then compounds 2, 1 and 4 (each within the scatter of the next).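

In this assay, the group on this aromatic carbon, para to a large group, clearly matters: trifluoromethyl in place of methyl gives a 3.9-fold higher number from compound 3 to compound 4 (0.59 log units; beyond the scatter), so this single exchange is enough to weaken inhibition. The earlier compounds shown here showed a change of the whole aryl group, whereas this result isolates the effect of one group on the ring. The comparison of the two halogen-bearing aryl groups gives a 1.7-fold higher number from compound 2 to compound 4 (0.24 log units; within the scatter), so 4-(trifluoromethyl)phenyl and 3,4-dichlorophenyl cannot be told apart here, and each stands clearly weaker than 4-methylphenyl, the group of compound 3 at 4.8 ug/mL.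

From the compounds shown here alone, whether a hydroxyl group, an amine or a single fluorine at this place would hold the number near that of compound 3 remains open. The compounds shown also offer no measurement that explains why trifluoromethyl weakens inhibition relative to methyl.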